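From Benzyl to 2-Hydroxyphenyl on an Amide-Type Nitrogen

The source may report more compounds than this note shows. Statements on the series, on what has been measured and on what is new or still open speak of the compounds shown alone.

- compound 1 `CC1=C(/C=C/C(C)=C/C=C/C(C)=C\C(=O)Nc2ccccc2)C(C)(C)CCC1n1ccnc1` (1730 nM)
- compound 2 `CC1=C(/C=C/C(C)=C/C=C/C(C)=C\C(=O)NCc2ccccc2)C(C)(C)CCC1n1ccnc1` (10700 nM)

Both values come from a functional assay on SK-BR-3 cells (Homo sapiens) for inhibition, read by MTT assay; a lower number here means a stronger inhibitor of growth, a higher number a weaker inhibitor of growth. Compound 2 has the higher of the two numbers, so it is the weaker growth inhibitor of the pair. Compound 3 `CC1=C(/C=C/C(C)=C/C=C/C(C)=C\C(=O)Nc2ccccc2O)C(C)(C)CCC1n1ccnc1` differs from compound 2 by one change: 2-hydroxyphenyl in place of benzyl on an amide-type nitrogen, which puts 2-hydroxyphenyl in place of benzyl on an amide-type nitrogen. Within the data shown here, the one measured step that bears on this is a 6.2-fold higher number from compound 1 to compound 2 (0.79 log units; beyond the scatter), a modest step with benzyl in place of phenyl at that same place. Among the measured compounds shown here, since 2-hydroxyphenyl is again a phenyl group, a lower number is expected in this assay, although no measured compound carries 2-hydroxyphenyl. The estimated step is a 5.4-fold lower number from compound 2 to compound 3 (0.73 log units; beyond the scatter) and is about as large as the step just given. The estimate for compound 3 is 2000 nM, with an expected range from 600 nM to 7000 nM for the coming measurement.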

Compound 3, concentration for 50% growth inhibition: 3890 nM
Compound 3: middle estimate off by 1.9-fold (0.29 log units), on the low side; the range from low to high includes it.
By their numbers in this assay, from the lowest: compound 1; then compound 3; then compound 2.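

Returning from benzyl to an aromatic ring carried directly on the amide-type nitrogen restores part of the growth inhibition in this assay, with a 2.8-fold lower number from compound 2 to compound 3 (0.44 log units; beyond the scatter). This shows that the advantage over benzyl seen with compound 1 also appears with a second group on that nitrogen. The hydroxy group itself does not help, however: hydroxy in place of hydrogen on an aromatic carbon gives a 2.2-fold higher number from compound 1 to compound 3 (0.35 log units; beyond the scatter), which leaves compound 1, with its unsubstituted phenyl, the strongest of the three.

As far as these compounds go, it remains open how a methoxy group, an amine or a carboxylic acid in place of the hydroxy group would compare. No available evidence explains why adding the hydroxy group raises the number.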